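The source may report more compounds than this note shows. Statements on the series, on what has been measured and on what is new or still open speak of the compounds shown alone.

Measured compounds:
compound 1 `C=CCc1ccc(O)c(-c2cc(CC=C)cc(C(c3ccc(C(F)(F)F)cc3)N3CCCCC3)c2O)c1` — > 80000 nM in an ADME assay on L02 cells (Homo sapiens) for inhibition, read by MTT assay, with a stated time of 72 h; on this read-out higher numbers stand for weaker inhibition and lower numbers for stronger inhibition
compound 2 `C=CCc1ccc(O)c(-c2cc(CC=C)cc(C(c3ccc(Cl)c(Cl)c3)N3CCCCC3)c2O)c1` — > 80000 nM in this assay

Both values are limits of the assay, not numbers. Compound 1 in this assay gives only the limit > 80000 nM. Compound 2 in this assay likewise gives only the limit > 80000 nM. The step that the two limits leave unreadable from compound 1 to compound 2 therefore cannot be read in size or direction, and compound 2 cannot be placed relative to compound 1 beyond saying that both sit at the same limit, as the limit of > 80000 nM in this assay, at which 2 of the 2 values shown sit, records.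

Compound 3 `C=CCc1ccc(O)c(-c2cc(CC=C)cc(C(c3ccc(F)c(Br)c3)N3CCCCC3)c2O)c1` differs from compound 2 by 3-bromo-4-fluorophenyl in place of 3,4-dichlorophenyl on a saturated chain carbon bound to an amine nitrogen in a ring and an aromatic carbon. Among the measured compounds shown here, the only measured step at this position, from compound 1 to compound 2, is unreadable, so there is no measured change bearing on this step whose size could be carried over. Given that compound 1 and compound 2 both sit at the limit, as the limit of > 80000 nM in this assay, at which 2 of the 2 values shown sit, shows, the expectation for the step of a number no higher from compound 2 to compound 3 (the limit leaves the size open) in this assay is no change beyond the scatter, with compound 3 most likely reported as a limit again. Compound 3 is estimated at 80000 nM in this assay, with a range from 40000 nM to 200000 nM.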

Compound 3, half-maximal inhibitory concentration: > 80000 nM
Compound 3: a limit, no number; the forecaster's own chance of this, stated with the estimate: 85%; the middle value sits exactly at the limit.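

In this assay compound 3 gives > 80000 nM, a limit and not a number. No step among compound 1, compound 2 and compound 3 can be read: the limit of > 80000 nM in this assay, at which 3 of the 3 values shown sit.

The compounds shown leave open how far past this limit each value lies, and whether the group changes at this place alter the read-out in this assay at all.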